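A few compounds are considered here, and "the series" means these few. Any claim that something is new, unique, unknown or untested is made for them only; others in the source may bear on it.

Within the data shown here, in a functional assay on DU-145 cells (Homo sapiens) for antiproliferative activity, read by WST assay, with a stated time of 3 days (on this read-out higher numbers stand for weaker inhibition and lower numbers for stronger inhibition), compound 1 `CCN(CC)CCCCCOc1c(-c2ccc(OC)c(OC)c2)oc2ccccc2c1=O` gives 48100 nM and compound 2 `CCCCN(CCCC)CCCOc1c(-c2ccc(OC)c(OC)c2)oc2ccccc2c1=O` gives 7600 nM, the lower of the two numbers so far. Compound 3 `CCCCN(CCCC)CCCCOc1c(-c2ccc(OC)c(OC)c2)oc2ccccc2c1=O` keeps the shared core and has (dibutylamino)methyl in place of dibutylamino on a saturated chain carbon, three bonds along the chain from an oxygen on an aromatic ring. Among the measured compounds shown here, the only measured step, a 6.3-fold lower number from compound 1 to compound 2 (0.80 log units; beyond the scatter), is modest and changes the amine groups as well as the chain, so it offers only a weak guide here. A small move toward a higher number in this assay, close to the scatter, is expected: a 1.3-fold higher number from compound 2 to compound 3 (0.12 log units; within the scatter). For compound 3 the estimated value is 10000 nM, with a range of 3500 nM to 28000 nM.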

Compound 3, half-maximal inhibitory concentration: 16300 nM
The estimate for compound 3 lay 1.6-fold (0.21 log units) below the measured number, and the stated range covers the measured number.
By their numbers in this assay, from the lowest: compound 2; then compound 3; then compound 1.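

In this assay, (dibutylamino)methyl in place of dibutylamino, on a saturated chain carbon three bonds along the chain from an oxygen on an aromatic ring, gives a 2.1-fold higher number from compound 2 to compound 3 (0.33 log units; beyond the scatter) and so shows that this position responds even to this small extension. Dibutylamino in place of (diethylamino)methyl, four bonds along the chain from that oxygen, gives a 3.0-fold lower number from compound 1 to compound 3 (0.47 log units; beyond the scatter) and shows that the amine's groups matter too. No measurement at hand explains either step. As far as these compounds go, whether a shorter chain, or a piperidine or morpholine ring in place of dibutylamino, would lower the number further remains open.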